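The source may report more compounds than this note shows. Statements on the series, on what has been measured and on what is new or still open speak of the compounds shown alone.

Measured so far:
- compound 1, `COc1ccc(CN(C(=O)C(C)Br)c2cc(OC)c(OC)c(OC)c2)cc1O`: 120 nM
- compound 2, `COc1ccc(N(Cc2cc(OC)c(OC)c(OC)c2)C(=O)CCl)cc1O`: 24500 nM

Both compounds were tested in a functional assay on MGC-803 cells (Homo sapiens) for inhibition, read by MTT assay, with a stated time of 48 h; a lower number here means a stronger inhibitor, a higher number a weaker inhibitor. Compound 1 has the lower of the two numbers and therefore the stronger inhibition; compound 2 sits at a much higher number, a gap that lies well beyond the usual scatter of this assay. These two compounds differ in more than one place, so their two values are all that can be said of that pair.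

The compound that has not yet been measured is compound 3, `COc1ccc(CN(C(=O)CCCCCl)c2cc(OC)c(OC)c(OC)c2)cc1O`. It keeps the whole of compound 1 apart from the group on the carbonyl carbon: 4-chlorobutyl in place of 1-bromoethyl on a carbonyl carbon. The chain that enters is longer by two carbons, and the halogen changes from bromine to chlorine.

Among the measured compounds shown here, no measured pair shows exactly this change, so the expectation rests on compound 1 alone. The step from compound 1 to compound 3 in this assay is expected to go towards weaker inhibition, by about a 25-fold higher number from compound 1 to compound 3 (1.40 log units; beyond the scatter). Compound 3 is accordingly estimated at 3000 nM, with a range from 300 nM to 30000 nM.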

Compound 3, half-maximal inhibitory concentration: 540 nM
Compound 3: the middle estimate sits 5.6-fold (0.74 log units) above what was measured; low and high end bracket the measured number.
By their numbers in this assay, from the lowest: compound 1; then compound 3; then compound 2.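

In this assay, among the compounds shown here, this result gives the first direct reading of the group on the carbonyl carbon, since the two earlier compounds differ in more than one place. Putting 4-chlorobutyl in place of 1-bromoethyl produces a 4.5-fold higher number from compound 1 to compound 3 (0.65 log units; beyond the scatter) and so counts as a real loss, though a modest one, and it shows that the number responds to this position without being lost altogether: compound 3 still gives 540 nM in this assay with the longer chain and the different halogen. Nothing available explains the size or direction of this step.

The step changes the chain and the halogen together, so it remains open which of the two accounts for the loss; 4-bromobutyl or 1-chloroethyl on the same carbonyl carbon would each separate them. Also open, going by these compounds, is whether a halogen is needed here at all, a question that a plain butyl chain, or a chain ending in an amine, could address.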